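A few compounds are considered here, and "the series" means these few. Any claim that something is new, unique, unknown or untested is made for them only; others in the source may bear on it.

Compound 1 `Brc1cn2ccnc2c(-c2ccc3ncn(C4CCCCC4)c3c2)n1` gives 17.2% in a functional assay on PC-3 cells (Homo sapiens) for inhibition, read by sulforhodamine B assay, with a stated time of 48 h, tested at 10 uM; on this read-out higher numbers stand for more inhibition at the one concentration tested (going by the name of the read-out) and lower numbers for less inhibition. Compound 2 `COc1ccc(-c2cn3ccnc3c(-c3ccc4ncn(C5CCCCC5)c4c3)n2)cc1` gives 95.2% in this assay. Compound 3 `O=Cc1ccc(-c2cn3ccnc3c(-c3ccc4ncn(C5CCCCC5)c4c3)n2)cc1` gives 19% in this assay.

Of the three, compound 2 stands highest, with a number 76.2 percentage points lower from compound 2 to compound 3 (beyond the scatter) and, looking back from compound 1, a number 78 percentage points higher from compound 1 to compound 2 (beyond the scatter); both of these gaps are beyond the scatter. Compound 4 `CC(=O)c1ccc(-c2cn3ccnc3c(-c3ccc4ncn(C5CCCCC5)c4c3)n2)cc1` has not yet been measured. It differs from compound 2 in one place: acetyl in place of methoxy on an aromatic carbon.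

For the measured compounds named here, two measured steps bear on this change. The step of a number 1.8 percentage points higher from compound 1 to compound 3 (within the scatter) shows that a 4-formylphenyl group in place of bromo adds nothing beyond the scatter, while the step of a number 76.2 percentage points lower from compound 2 to compound 3 (beyond the scatter) shows that trading methoxy for formyl at the same place removes almost all of the inhibition seen for compound 2. Acetyl shares with formyl a double bond outside aromatic rings and a single hydrogen-bond acceptor, and it likewise lacks the methoxy group that marks compound 2. Going by the values given here, the expectation is therefore a large step downward in this assay for compound 4, of roughly the size seen between compound 2 and compound 3, though the data hold no direct acetyl example, so the range is kept wide. The estimate for compound 4 is 25%, between 8% and 55%, which means an expected step of a number 70.2 percentage points lower from compound 2 to compound 4 (beyond the scatter).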

Compound 4, a percentage reported as inhibition, at one concentration (the size of the read-out at that concentration, not a potency): 17.9%
Beside the measured number, compound 4's estimate is 7.1 percentage points above it; the measured number falls inside the stated range.
By their numbers in this assay, from the lowest: compounds 1, 4 and 3 (each within the scatter of the next); then compound 2.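

In this assay, the step of a number 1.1 percentage points lower from compound 3 to compound 4 (within the scatter) shows that a methyl group on the carbonyl carbon makes no difference that can be told from the scatter, so acetyl and formyl cannot be separated at this place, para to a large group. The step of a number 77.3 percentage points lower from compound 2 to compound 4 (beyond the scatter) means that the large fall from the methoxy compound now appears with two different carbonyl groups, so it is not a peculiarity of formyl alone. The step of a number 0.7 percentage points higher from compound 1 to compound 4 (within the scatter) adds that 4-acetylphenyl, like 4-formylphenyl, cannot be told apart from plain bromo, so among these compounds a phenyl ring at this place does not by itself bring high inhibition, and only the 4-methoxyphenyl of compound 2 does.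

Nothing available here explains why methoxy and these carbonyl groups give such different results. On these data alone, it remains open whether the high inhibition is particular to methoxy or would also be seen with ethoxy, a hydroxyl group, an amine or a carboxylic acid at this place, and a reading at one concentration gives no measure of potency for any of them.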